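The compounds below may be only part of what the source reports. "The series", "measured", "known", "first", "only" and "open" are said of these compounds alone.

Compound 1 `Cc1cc(Nc2cc(N3CCN(C)CC3)nc(Nc3ccc([N+](=O)[O-])cc3)n2)n[nH]1` gives 137 nM
Compound 2 `Cc1cc(Nc2cc(N3CCN(C)CC3)nc(Nc3ccc(Cl)cc3)n2)n[nH]1` gives 192 nM

These two numbers come from a functional assay on K562 cells (Homo sapiens) for antiproliferative activity, read by CCK-8 assay, with a stated time of 72 h (on this read-out lower numbers stand for stronger inhibition and higher numbers for weaker inhibition), and lie within the scatter of each other, so compound 2 stands level with compound 1 and neither can be ranked ahead of the other. The next compound, compound 3 `Cc1cc(Nc2cc(N3CCN(C)CC3)nc(Nc3ccc(C#N)cc3)n2)n[nH]1`, has not yet been measured. It differs from compound 2 in one place, with cyano in place of chloro on an aromatic carbon, para to a large group (cyano in place of chloro on an aromatic carbon). Among the measured compounds shown here, the one measured step at this place is a 1.4-fold higher number from compound 1 to compound 2 (0.15 log units; within the scatter) with chloro in place of nitro, so swapping the group there has so far moved the number no further than the scatter. A single step is thin evidence, yet it gives no reason to expect a shift beyond the scatter in this assay in either direction. The expected change is a 1.2-fold lower number from compound 2 to compound 3 (0.07 log units; within the scatter) by this estimate. For compound 3 the estimated value is 165 nM with an expected range from 85 nM to 330 nM as the likely span.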

Compound 3, half-maximal inhibitory concentration: 58.1 nM
Compound 3: the middle estimate sits 2.8-fold (0.45 log units) above what was measured, outside the stated range (below it).
By their numbers in this assay, from the lowest: compound 3; then compounds 1 and 2 (each within the scatter of the next).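

Read in this assay this position proves sensitive to the group it carries: cyano in place of chloro brings a 3.3-fold lower number from compound 2 to compound 3 (0.52 log units; beyond the scatter) and cyano in place of nitro brings a 2.4-fold lower number from compound 1 to compound 3 (0.37 log units; beyond the scatter) whereas the earlier swap alone, a 1.4-fold higher number from compound 1 to compound 2 (0.15 log units; within the scatter) gave no sign of this. The aromatic carbon para to a large group therefore cannot be treated as a spot where any of these groups will do, since cyano stands apart from both others while nitro and chloro stay level with each other, and compound 3 is the strongest of the three on this read-out. No measurement at hand says what lies behind the gain from cyano, so the result remains an observation and not an explanation.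

As far as these compounds go, three groups at one carbon make a short series, so it remains open whether a methoxy, a trifluoromethyl, an amine or a carboxylic acid at the same place would match cyano, fall back level with chloro and nitro or go beyond all three. From the compounds shown here alone, it is also open whether cyano would bring a similar step on a core carrying a different group in place of the methylpiperazine-bearing part shared by these compounds.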